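Replacing the Oxetanyl Group on the Amide Nitrogen

The source may report more compounds than this note shows. Statements on the series, on what has been measured and on what is new or still open speak of the compounds shown alone.

Compound 1 `Cc1ccc(OCC(=O)N(Cc2cccs2)C2COC2)cc1`: 23000 nM
Compound 2 `CCN(Cc1ccco1)C(=O)COc1ccc(C)cc1`: 489 nM

In an assay on HEK293 cells for agonist activity at transient receptor potential cation channel subfamily M member 8 (Homo sapiens), read by fluorescence and calcium flux, with a stated time of 15 min (a lower number here means that less compound is needed, a higher number that more compound is needed for the effect), compound 1 gives 23000 nM, the highest of the two numbers recorded, while compound 2 gives 489 nM, a gap well beyond the usual scatter. Going by the values given here, no single-change pair connects these two compounds, so their values stand on their own. Compound 3 `Cc1ccc(OCC(=O)N(O)Cc2cccs2)cc1` has not yet been measured. It differs from compound 1 in one place: hydroxy in place of oxetan-3-yl on an amide-type nitrogen. Among the compounds with values here, with no measured step of this kind available, the account expects a modest move toward a lower number, a 3.8-fold lower number from compound 1 to compound 3 (0.58 log units; beyond the scatter), carrying wide uncertainty. Compound 3 is therefore estimated at 6000 nM, spanning 1500 nM to 30000 nM.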

Compound 3, half-maximal effective concentration: 8000 nM
Estimate against measurement, compound 3: 1.3-fold (0.12 log units) below; low and high end bracket the measured number.
By their numbers in this assay, from the lowest: compound 2; then compound 3; then compound 1.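

Going by these compounds alone, putting hydroxy in place of oxetan-3-yl on the amide-type nitrogen gives the first measured step at this position in this assay: a 2.9-fold lower number from compound 1 to compound 3 (0.46 log units; beyond the scatter), a modest change. The position therefore accepts a group of a single heavy atom, with no ring, in place of the four-membered ring, and the number still falls. No evidence is available on why the number moves. Still open, as far as these compounds go, is how a methoxy group or an amine on this nitrogen would compare with hydroxy. Also open, from the compounds shown here alone, is where a longer chain there would fall.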